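The source may hold more compounds than are shown below. What is called first, only, known or untested is meant among the compounds shown, and "the series" means these compounds.

The three measured compounds share one core and differ only in the group carried on the ring nitrogen of the outer ring. In an assay on striatum for inhibition of 5-hydroxytryptamine receptor 4 (Cavia porcellus), read by radioligand binding (on this read-out lower numbers stand for stronger inhibition and higher numbers for weaker inhibition), compound 1 `COc1cc(N)c(Cl)cc1C(=O)NC1CCN(CC2CCN(C(=O)CCCN)CC2)CC1` gives 3.99 nM. Compound 2 `COc1cc(N)c(Cl)cc1C(=O)NC1CCN(CC2CCN(CC(C)CN)CC2)CC1` gives 14.3 nM in this assay, and compound 3 `CCCC(N)C(=O)N1CCC(CN2CCC(NC(=O)c3cc(Cl)c(N)cc3OC)CC2)CC1` gives 2.57 nM. Compound 3 thus holds the lowest of the three numbers, but the step of a 1.6-fold lower number from compound 1 to compound 3 (0.19 log units; within the scatter) lies within the scatter, so compound 1 and compound 3 cannot be told apart, whereas the step of a 5.6-fold lower number from compound 2 to compound 3 (0.75 log units; beyond the scatter) does separate compound 3 from compound 2.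

Compound 4 `COc1cc(N)c(Cl)cc1C(=O)NC1CCN(CC2CCN(C(=O)C(C)N)CC2)CC1` is the next member. Relative to compound 3 the change is hydrogen in place of ethyl on a saturated chain carbon, two bonds along the chain from an amine nitrogen and a carbonyl carbon. Among the compounds with values here, the one measured step that bears on it is the exchange on the carbonyl carbon, a 1.6-fold lower number from compound 1 to compound 3 (0.19 log units; within the scatter), which stayed within the scatter; the steps of a 3.6-fold higher number from compound 1 to compound 2 (0.55 log units; beyond the scatter) and a 5.6-fold lower number from compound 2 to compound 3 (0.75 log units; beyond the scatter) concern loss or gain of the carbonyl itself and are less informative here, since compound 4 keeps the carbonyl. Compound 4 is therefore expected to show a step of about a 1.4-fold higher number from compound 3 to compound 4 (0.13 log units; within the scatter) in this assay, none beyond the scatter. Compound 4 is estimated at 3.5 nM, with a range from 1.5 nM to 8 nM.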

Compound 4, half-maximal inhibitory concentration: 5.06 nM
The estimate for compound 4 lay 1.4-fold (0.16 log units) below the measured number; the measured number falls inside the stated range.
By their numbers in this assay, from the lowest: compounds 3, 1 and 4 (each within the scatter of the next); then compound 2.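

In this assay, taking the ethyl off this saturated chain carbon, which turns 1-aminobutyl into 1-aminoethyl, gives a 2.0-fold higher number from compound 3 to compound 4 (0.29 log units; within the scatter) and so leaves compound 4 inseparable from compound 3 on this read-out, while the exchange of 3-aminopropyl for 1-aminoethyl on the carbonyl carbon gives a 1.3-fold higher number from compound 1 to compound 4 (0.10 log units; within the scatter) and likewise stays inside the scatter. The carbonyl-bearing side groups of compound 1, compound 3 and compound 4 thus differ in chain length and in where the amine sits, yet the steps among them do not resolve them, whereas a 2.8-fold lower number from compound 2 to compound 4 (0.45 log units; beyond the scatter) still sets compound 2 apart, even with the shortest of these groups. Nothing at hand gives a reason for these numbers.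

The compounds shown leave open whether a propyl, a phenyl ring or a carboxylic acid on this saturated chain carbon would stay within the scatter of hydrogen and ethyl. They also leave open whether the gap to compound 2 belongs to the carbonyl alone, since that compound's 2-(aminomethyl)propyl group could be tested against an unbranched aminoalkyl chain on the same ring nitrogen.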